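A few compounds are considered here, and "the series" means these few. Any claim that something is new, unique, unknown or untested is made for them only; others in the source may bear on it.

Compound 1 `S=C(N/N=C/c1cccs1)Nc1ccccc1` and compound 2 `S=C(N/N=C/c1cccs1)Nc1cccc2ccccc12` share a thiosemicarbazone core and were tested in a functional assay on U-251 cells (Homo sapiens) for inhibition, read by sulforhodamine B assay, with a stated time of 48 h; on this read-out lower numbers stand for stronger inhibition of growth and higher numbers for weaker inhibition of growth. In this assay compound 1 gives 74700 nM, the higher of the two numbers, so it is the weaker inhibitor of cell growth. In this assay compound 2 gives 12700 nM; the two values are far enough apart to lie beyond the usual scatter of repeated runs. Compound 3 `CCc1ccc(NC(=S)N/N=C/c2cccs2)cc1` has not yet been measured in this assay. It differs from compound 1 in one place: ethyl in place of hydrogen on an aromatic carbon. Here a small group is added to the ring instead of the ring being enlarged as in compound 2, so a milder shift is expected. Compound 3 is expected to give about 35000 nM in this assay, with a plausible range from 12000 nM to 90000 nM. That estimate corresponds to an expected step of a 2.1-fold lower number from compound 1 to compound 3 (0.33 log units; beyond the scatter), at the edge of the scatter.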

Compound 3, concentration for 50% growth inhibition: > 100000 nM
Compound 3 ended at the assay's limit (the forecaster's own chance of this, stated with the estimate: 5%); middle value at least 2.8-fold (0.45 log units) away from the limit.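

Compound 3 puts a group on this aromatic carbon, para to a large group, for the first time among the compounds shown, and ethyl there brings no gain in growth inhibition over compound 1. In this assay compound 3 gives > 100000 nM, which is a limit of the assay and not a number. As far as these compounds go, the change therefore reads only as an at least 1.3-fold higher number from compound 1 to compound 3 (0.12 log units; that floor lies within the scatter), so the true distance between the two compounds stays unknown: the limit of > 100000 nM in this assay, at which 1 of the 3 values shown sits.

From the compounds shown here alone, whether a group other than ethyl at this position, such as methyl, methoxy, an amine or a carboxylic acid, would keep or improve the growth inhibition of compound 1 remains open. Going by these compounds, whether a longer chain there would behave like ethyl also remains open.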